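Sulfide to sulfone on the shared pyrazolopyrimidine-type core

This account rests on a few compounds, and the source may have more. Where it says the series, first, only, none or still open, it means among the compounds named here.

Measured so far in an assay on isolated protein for binding affinity to corticotropin-releasing factor receptor 1 (Homo sapiens); on this read-out higher numbers stand for weaker inhibition and lower numbers for stronger inhibition:
compound 1 `CCCN(CCC)c1cc(CC)nc2c(-c3ccc(Cl)cc3)c(C)nn12` gives 100 nM;
compound 2 `CCCN(CC1CC1)c1cc(SC)nc2c(-c3ccc(Cl)cc3Cl)c(C)nn12` gives 0.73 nM;
compound 3 `CCCN(CCC)c1cc(C)nc2c(-c3ccc(C(=O)O)cc3)c(C)nn12` gives only a limit, > 10000 nM.

Compound 2 holds the lowest of the two numbers shown. Compound 1 stands at a higher number, and the gap lies well beyond the scatter. For compound 3 the read-out is the limit of > 10000 nM in this assay, at which 1 of the 3 values shown sits, which is a limit and not a number.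

Compound 4 `CCCN(CC1CC1)c1cc(S(C)(=O)=O)nc2c(-c3ccc(Cl)cc3Cl)c(C)nn12` differs from compound 2 in one place: methylsulfonyl in place of methylsulfanyl on an aromatic carbon. Among the compounds with values here, no pair of measured compounds covers a change of this kind, so the expectation for compound 4 rests on compound 2 and its value of 0.73 nM together with the size of the group that enters. A step toward a higher number, beyond the scatter, is expected. The expected step from the sulfide to the sulfone is a 27-fold higher number from compound 2 to compound 4 (1.44 log units; beyond the scatter). Compound 4 is estimated at 20 nM, with a range from 3 nM to 300 nM.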

Compound 4, inhibition constant: 150 nM
Compound 4: middle estimate off by 7.5-fold (0.88 log units), on the low side; the measured number falls inside the stated range.
By their numbers in this assay, from the lowest: compound 2; then compounds 1 and 4 (each within the scatter of the next). At a limit, above all of these: compound 3.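

In this assay, within the data shown here, replacing methylsulfanyl with methylsulfonyl on the aromatic carbon next to the ring nitrogen gives a 210-fold higher number from compound 2 to compound 4 (2.31 log units; beyond the scatter) and is the first change that can be read at a single place. With the rest of compound 2 held fixed, the read-out responds strongly to the group on this carbon, so a sulfur-linked methyl group at this position does not by itself secure a low number. No measurement shown bears on the cause of this step.

On these data alone, whether the step follows from the two added oxygens or from the larger group remains open. Methylsulfinyl, methoxy or a dimethylamino group on the same carbon, set on the otherwise unchanged structure of compound 2, would help separate these two readings.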